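Working notes: the step from compound 2 to compound 3

A few compounds are considered here, and "the series" means these few. Any claim that something is new, unique, unknown or untested is made for them only; others in the source may bear on it.

Compound 1 `Cc1cc(C)c(S(=O)(=O)N2CCC(N3CCC(c4ccccc4)CC3)CC2)c(C)c1` gives > 5000 nM
Compound 2 `Cc1ccc(C2CCN(S(=O)(=O)c3c(C)cc(C)cc3C)CC2)cc1` gives > 5000 nM

Both entries come from an ADME assay on HCT-116 cells (Homo sapiens) for cytotoxicity, read by CellTiter-Glo, with a stated time of 72 h (on this read-out higher numbers stand for weaker inhibition and lower numbers for stronger inhibition), and both are limits, not numbers. Compound 2 therefore has no number of its own and sits, together with compound 1, at the limit of > 5000 nM in this assay, at which 2 of the 2 values shown sit, in the notes so far.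

Compound 3 `Cc1cc(C)c(S(=O)(=O)N2CCC(N3CCC(C(C)C)CC3)CC2)c(C)c1` has 4-isopropylpiperidin-1-yl in place of 4-methylphenyl on a saturated ring carbon. The change 4-isopropylpiperidin-1-yl in place of 4-methylphenyl on a saturated ring carbon is the one followed here.

Among the measured compounds shown here, no measured step exists to size it. In this assay no step beyond the scatter is expected, and compound 3 will probably return a limit as well. That expectation rests on compound 1 and compound 2 at the limit of > 5000 nM in this assay, at which 2 of the 2 values shown sit, alone. The expected change is a step that the limit leaves unreadable from compound 2 to compound 3 and would lie within the scatter. For compound 3 the estimated value is 7000 nM with an expected range of 3000 nM to 15000 nM if a number is reported.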

Compound 3, half-maximal inhibitory concentration: > 5000 nM
Compound 3 ended at the assay's limit (the forecaster's own chance of this, stated with the estimate: 80%); the middle value lies beyond the limit too.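

No step can be read from compound 3 to compound 1 or compound 2, since each value is a limit and not a number: the limit of > 5000 nM in this assay, at which 3 of the 3 values shown sit.

The compounds shown leave open how far these three differ in this assay and which change to the shared core would return a number instead of a limit.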